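Hydroxy to amino on the shared core: compound 3

The source may report more compounds than this note shows. Statements on the series, on what has been measured and on what is new or still open speak of the compounds shown alone.

In a functional assay on SNU-638 cells (Homo sapiens) for cytotoxicity, read by sulforhodamine B assay, with a stated time of 72 h (on this read-out higher numbers stand for weaker inhibition and lower numbers for stronger inhibition), compound 1 (`OCC1=C(F)[C@@H](n2cnc3c(O)ncnc32)[C@H](O)[C@@H]1O`) gives > 100000 nM, which is a limit and not a number. Compound 2 (`Nc1nc(O)c2ncn([C@@H]3C(F)=C(CO)[C@@H](O)[C@H]3O)c2n1`) gives > 100000 nM, again a limit of the assay. Compound 2 therefore has no numeric place in the series, and the whole picture so far is the limit of > 100000 nM in this assay, at which 2 of the 2 values shown sit.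

Compound 3 (`Nc1nc(N)c2ncn([C@@H]3C(F)=C(CO)[C@@H](O)[C@H]3O)c2n1`) is reached from compound 2 by amino in place of hydroxy on an aromatic carbon, on a six-membered aromatic ring with 2 nitrogen, part of a fused or bridged system of two rings: amino in place of hydroxy on an aromatic carbon.

Going by the values given here, one measured step bears on this change, a step that the two limits leave unreadable from compound 1 to compound 2, and it sets no scale. No size can therefore be carried over, and a second reading at the limit in this assay is a real possibility. Only a move toward stronger inhibition could appear as a number, so the expected change is an at least 2.5-fold lower number from compound 2 to compound 3 (0.39 log units; beyond the scatter), with wide uncertainty. For compound 3, the estimated value is 40000 nM. The expected range for compound 3 runs from 3000 nM to 100000 nM.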

Compound 3, half-maximal inhibitory concentration: 32200 nM
Beside the measured number, compound 3's estimate is 1.2-fold (0.09 log units) above it; the measured number falls inside the stated range.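

Amino in place of hydroxy on this aromatic carbon, next to the ring nitrogen, gives the series its first numeric reading in this assay, with an at least 3.1-fold lower number from compound 2 to compound 3 (0.49 log units; beyond the scatter). Hydroxy and amino match in heavy atoms, hydrogen-bond donors, hydrogen-bond acceptors and net charge, so these counts do not separate the two groups, yet the read-out does, and the position is now shown to respond to substitution. The earlier step cannot be read, and the numeric reading for compound 3 stands against a series otherwise held at a limit of the assay: the limit of > 100000 nM in this assay, at which 2 of the 3 values shown sit.

On these data alone, whether the same exchange would register without the amino group meta to this position, as on the core of compound 1, stays open. Also open, as far as these compounds go, is how far the trend runs at this carbon: a methylamino or dimethylamino group, a methoxy group or a chlorine atom would show whether the number depends on the amino group itself or moves further with other replacements for hydroxy.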